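Methoxy to methylamino on the core of compound 1

The source may report more compounds than this note shows. Statements on the series, on what has been measured and on what is new or still open speak of the compounds shown alone.

Measured in a functional assay on HCT-116 cells (Homo sapiens), read by MTT assay, with a stated time of 72 h; on this read-out lower numbers stand for stronger inhibition and higher numbers for weaker inhibition:
compound 1 `COc1ncnc2c1c(-c1ccsc1)cn2[C@@H]1O[C@H](CO)[C@@H](O)[C@H]1O`: 120 nM
compound 2 `COc1nc(N)nc2c1c(-c1ccsc1)cn2[C@@H]1O[C@H](CO)[C@@H](O)[C@H]1O`: > 20000 nM, a limit of the assay
compound 3 `COc1ncnc2c1c(-c1ccccc1)cn2[C@@H]1O[C@H](CO)[C@@H](O)[C@H]1O`: > 20000 nM, a limit of the assay

Going by the values given here, compound 1 holds the only numerical value in this assay; the two other results are limits, and the limit of > 20000 nM in this assay, at which 2 of the 3 values shown sit, marks where both sit. The step of an at least 160-fold higher number from compound 1 to compound 2 (2.22 log units; beyond the scatter) is large, and an at least 160-fold higher number from compound 1 to compound 3 (2.22 log units; beyond the scatter) is equally large; neither of these changes involves the methoxy group. Compound 4 `CNc1ncnc2c1c(-c1ccsc1)cn2[C@@H]1O[C@H](CO)[C@@H](O)[C@H]1O` differs from compound 1 by methylamino in place of methoxy on an aromatic carbon. Among the compounds with values here, no measured step bears on this change, so the expectation rests on compound 1 alone and is set wide. The estimate for compound 4 is 100 nM, with a range of 20 nM to 800 nM. The step of a 1.2-fold lower number from compound 1 to compound 4 (0.08 log units; within the scatter) is expected to lie within the scatter.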

Compound 4, half-maximal inhibitory concentration: > 20000 nM
Compound 4 was reported as a limit; the forecaster's own chance of this, stated with the estimate: 10%; at least 200-fold (2.30 log units) between middle value and limit.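

In this assay, the position carrying the methoxy group now proves as sensitive as the two sites changed earlier, with an at least 160-fold higher number from compound 1 to compound 4 (2.22 log units; beyond the scatter). The swap to methylamino keeps the count of 2 heavy atoms and adds 1 hydrogen-bond donor, yet compound 4 gives only a limit of the assay: the limit of > 20000 nM in this assay, at which 3 of the 4 values shown sit.

Going by these compounds alone, with compound 1 the only numerical value, the three changes cannot be ranked against each other. On these data alone, whether ethoxy or dimethylamino on this aromatic carbon would retain activity remains open, and with it whether the added donor or the nitrogen itself matters.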